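From Methyl to Diethylamino on the Aryl Ketone

The source may hold more compounds than are shown below. What is called first, only, known or untested is meant among the compounds shown, and "the series" means these compounds.

Compound 1 `COc1ccc(/C=C/c2cc(OC)cc(OC)c2/C=C/C(=O)c2cccc(Br)c2)cc1` and compound 2 `COc1ccc(/C=C/c2cc(OC)cc(OC)c2/C=C/C(=O)c2ccc(C)cc2)cc1` share one core and differ only in the aryl group on the carbonyl carbon. Among the compounds with values here, in a functional assay on A549 cells (Homo sapiens) for antiproliferative activity, read by MTT assay, with a stated time of 48 h (a lower number here means a stronger inhibitor, a higher number a weaker inhibitor), compound 1 gives 8.1 ug/mL, while compound 2 gives 3.6 ug/mL; the step of a 2.3-fold lower number from compound 1 to compound 2 (0.35 log units; beyond the scatter) leaves compound 2 with the lower of the two numbers measured so far. Compound 3 `CCN(CC)c1ccc(C(=O)/C=C/c2c(/C=C/c3ccc(OC)cc3)cc(OC)cc2OC)cc1` has not yet been tested. It differs from compound 2 in one place: diethylamino in place of methyl on an aromatic carbon. Within the data shown here, no measured pair shows this same change. Among the measured compounds shown here, the only step available, 4-methylphenyl in place of 3-bromophenyl on a carbonyl carbon, concerns a different part of the same ring and moved the result by a 2.3-fold lower number from compound 1 to compound 2 (0.35 log units; beyond the scatter), so it indicates only how far a change on this ring has shifted the number so far. For the measured compounds named here, with no direct precedent, compound 3 is expected to stay near compound 2, the estimated step being a 1.3-fold higher number from compound 2 to compound 3 (0.10 log units; within the scatter), which may lie within the scatter or slightly beyond it in either direction. Compound 3 is therefore estimated at 4.5 ug/mL in this assay, with a range of 1.6 ug/mL to 12 ug/mL.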

Compound 3, half-maximal inhibitory concentration: 5.4 ug/mL
The estimate for compound 3 lay 1.2-fold (0.08 log units) below the measured number; low and high end bracket the measured number.
By their numbers in this assay, from the lowest: compounds 2, 3 and 1 (each within the scatter of the next, the first and the last beyond it).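

In this assay, replacing methyl with diethylamino on an aromatic carbon para to a large group gives a 1.5-fold higher number from compound 2 to compound 3 (0.18 log units; within the scatter), so a change from one heavy atom to five, including a nitrogen, leaves compound 3 indistinguishable from compound 2 in this read-out. The comparison with the bromine-bearing analogue gives a 1.5-fold lower number from compound 1 to compound 3 (0.18 log units; within the scatter), which places compound 3 within the scatter of compound 1 as well, even though compound 1 and compound 2 are separated by a step beyond the scatter, so this one value cannot assign compound 3 to either side of that gap. No experimental information is available to explain why the number stays so close when this much larger group enters.

The compounds shown leave open whether this tolerance extends to other groups at the same place, such as a primary amine, a carboxylic acid or a morpholine ring. They also leave open whether longer chains on the nitrogen than the two ethyl groups of compound 3 would keep the number within the scatter of compound 2.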